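The source may report more compounds than this note shows. Statements on the series, on what has been measured and on what is new or still open speak of the compounds shown alone.

Going by the values given here, in a functional assay on DU-145 cells (Homo sapiens) for antiproliferative activity, read by WST assay, with a stated time of 3 days (a lower number here means a stronger inhibitor, a higher number a weaker inhibitor), the series so far holds only limits. Compound 1 (`CCCC(C)Oc1c(-c2cc(OC)c(OC)c(OC)c2)oc2ccccc2c1=O`) gives > 50000 nM as a limit of the assay. Compound 2 (`CCN(CC)CCCOc1c(-c2cc(OC)c(OC)c(OC)c2)oc2ccccc2c1=O`) gives > 50000 nM as a limit as well, so compound 2 stands without a number. The evidence on the series is the limit of > 50000 nM in this assay, at which 2 of the 2 values shown sit, alone. Among the compounds with values here, the only measured step is a step that the two limits leave unreadable from compound 1 to compound 2 and it offers no size to carry forward. Compound 3 (`CCN(CC)CCCCCOc1c(-c2cc(OC)c(OC)c(OC)c2)oc2ccccc2c1=O`) differs from compound 2 on the chain as follows: 2-(diethylamino)ethyl in place of diethylamino on a saturated chain carbon, three bonds along the chain from an oxygen on an aromatic ring. This places 2-(diethylamino)ethyl where diethylamino stood. With no readable step to draw on, only a modest move toward stronger inhibition is expected in this assay, and another reading at the limit is quite possible. The expected step is an at least 1.2-fold lower number from compound 2 to compound 3 (0.09 log units; that floor lies within the scatter) and it remains a rough estimate. For compound 3 the estimated value is 40000 nM within an expected range of 10000 nM to 80000 nM in this estimate.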

Compound 3, half-maximal inhibitory concentration: 33400 nM
Estimate against measurement, compound 3: 1.2-fold (0.08 log units) above, within the range that was stated.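

In this assay, going by these compounds alone, the 5-(diethylamino)pentyl chain yields the first reading that is a number and not a limit, so lengthening the chain at this place now has a readable floor: an at least 1.4-fold lower number from compound 2 to compound 3 (0.17 log units; that floor lies within the scatter). The comparison with the branched 1-methylbutyl ether gives the same floor, an at least 1.4-fold lower number from compound 1 to compound 3 (0.17 log units; that floor lies within the scatter), and each step starts from a limit, so its true size may be larger, while the floor alone does not go beyond the scatter. The series as a whole remains close to the edge of the assay: the limit of > 50000 nM in this assay, at which 2 of the 3 values shown sit.

As far as these compounds go, the true size of the step stays open, as compound 2 has no number. Also open, from the compounds shown here alone, is whether a longer chain, or a piperidine or morpholine in place of diethylamino, would lower the reading further.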